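The source may hold more compounds than are shown below. What is called first, only, known or untested is meant among the compounds shown, and "the series" means these compounds.

Measured in an ADME assay on MRC5 cells (Homo sapiens) for cytotoxicity, read by fluorescence, with a stated time of 72 h; a lower number here means a stronger inhibitor, a higher number a weaker inhibitor:
- Compound 1 `CC1(COc2ccccc2)Cn2cc([N+](=O)[O-])nc2O1`: > 64000 nM, a limit
- Compound 2 `CC1(COc2ccc(Cl)cc2)Cn2cc([N+](=O)[O-])nc2O1`: > 64000 nM, a limit
- Compound 3 `CC1(COc2ccc(C(F)(F)F)cc2)Cn2cc([N+](=O)[O-])nc2O1`: > 64000 nM, a limit

Compound 3 stands at > 64000 nM in this assay, which is a limit of the assay and not a number. The whole set rests at the limit of > 64000 nM in this assay, at which 3 of the 3 values shown sit.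

Compound 4 `CC1(COc2ccc(-c3ccc(C(F)(F)F)cc3)cc2)Cn2cc([N+](=O)[O-])nc2O1` differs from compound 3 in one place (4-(trifluoromethyl)phenyl in place of trifluoromethyl on an aromatic carbon). Here 4-(trifluoromethyl)phenyl comes in place of trifluoromethyl on an aromatic carbon of a six-membered aromatic ring of carbon only, para to a large group.

Among the compounds with values here, three measured steps bear on this change: a step that the two limits leave unreadable from compound 1 to compound 2, a step that the two limits leave unreadable from compound 1 to compound 3 and a step that the two limits leave unreadable from compound 2 to compound 3. None has a readable size, so together they give no measured direction. None of them brings in a further ring either, so compound 4 goes beyond what they cover. Hydrogen, chloro and trifluoromethyl all left the reading at the limit in this assay, so no step beyond the scatter is expected, although a reading that comes off the limit towards stronger inhibition remains possible.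

The step expected from this estimate is an at least 1.0-fold lower number from compound 3 to compound 4 (0.02 log units; that floor lies within the scatter). For compound 4 the estimated value is 60000 nM, with an expected range from 25000 nM to 64000 nM, and the assay may well report only its limit again.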

Compound 4, half-maximal inhibitory concentration: > 64000 nM
Compound 4 ended at the assay's limit (the forecaster's own chance of this, stated with the estimate: 70%); middle value at least 1.0-fold (0.02 log units) away from the limit.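

In this assay compound 4 gives > 64000 nM, which is a limit of the assay and not a number, so its steps from compound 1, compound 2 and compound 3 cannot be read. The compounds shown leave open what actual value any of them has and which change, if any, would bring a reading off the shared limit: the limit of > 64000 nM in this assay, at which 4 of the 4 values shown sit.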